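This account rests on a few compounds, and the source may have more. Where it says the series, first, only, none or still open, it means among the compounds named here.

Measured so far:
compound 1 `Cc1cc(C(N)=O)nn1Cc1cc(Cl)ccc1OCc1ccccc1` gives 126 nM
compound 2 `Cc1cc(C(=O)Nc2c(F)cccc2F)nn1Cc1cc(Cl)ccc1OCc1ccccc1` gives 10 nM
compound 3 `Cc1cc(NC(=O)c2c(F)cccc2F)nn1Cc1cc(Cl)ccc1OCc1ccccc1` gives 12.6 nM

In an assay on CHO-K1 cells for displacement of a labelled ligand from prostaglandin E2 receptor EP1 subtype (Homo sapiens) (on this read-out higher numbers stand for weaker inhibition and lower numbers for stronger inhibition), compound 2 gives the lowest of the three numbers, though compound 3 lies within the scatter of it, while compound 1 stands well above. Compound 4 `Cc1cc(NC(=O)O[C@H]2CCOC2)nn1Cc1cc(Cl)ccc1OCc1ccccc1` differs from compound 2 in one place: (((oxolan-3-yl)oxy)carbonyl)amino in place of (2,6-difluorophenyl)carbamoyl on an aromatic carbon. Among the measured compounds shown here, two measured steps bear on this change. The step of a 13-fold lower number from compound 1 to compound 2 (1.10 log units; beyond the scatter) covers the introduction of the 2,6-difluorophenyl group, and the step of a 1.3-fold higher number from compound 2 to compound 3 (0.10 log units; within the scatter) covers the reversed amide, which changed little. Compound 4 keeps a carbonyl-linked amino group but gives up the (2,6-difluorophenyl)carbamoyl group, so a moderate rise toward compound 1 is expected, a 5.0-fold higher number from compound 2 to compound 4 (0.70 log units; beyond the scatter). Compound 4 is therefore estimated at 50 nM, with a range from 15 nM to 200 nM.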

Compound 4, half-maximal inhibitory concentration: 79.4 nM
For compound 4 the middle estimate is 1.6-fold (0.20 log units) below the measured one; the range from low to high includes it.
By their numbers in this assay, from the lowest: compounds 2 and 3 (each within the scatter of the next); then compounds 4 and 1 (each within the scatter of the next).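

In this assay, (oxolan-3-yl)oxy does not match 2,6-difluorophenyl on the carbonyl carbon: the change gives a 6.3-fold higher number from compound 3 to compound 4 (0.80 log units; beyond the scatter), and the wider replacement gives a 7.9-fold higher number from compound 2 to compound 4 (0.90 log units; beyond the scatter). The carbonyl-linked amino group alone therefore does not keep the low numbers, and the comparison with the plain carbamoyl gives a 1.6-fold lower number from compound 1 to compound 4 (0.20 log units; within the scatter). Nothing at hand explains this result. The compounds shown leave open whether an unfluorinated phenyl or a cyclohexyl group on the same carbonyl would keep the numbers of compound 2 and compound 3, and whether the opposite configuration at the oxolane stereocentre would differ from compound 4.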